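Adding an Acetyl Group to the Outer Phenyl Ring

The compounds below may be only part of what the source reports. "The series", "measured", "known", "first", "only" and "open" are said of these compounds alone.

Three compounds share a core built around a five-membered ring bearing an amino group, a benzoyl group and a trifluoromethylphenyl group; they differ only at one aromatic carbon of that core. Compound 1 `Nc1sc(Br)c(-c2cccc(C(F)(F)F)c2)c1C(=O)c1ccccc1` carries bromo there and in an assay on CHO-K1 cells for displacement of a labelled ligand from adenosine receptor A1 (Homo sapiens), tested at 10 uM (a lower number here means less inhibition, a higher number more inhibition at the concentration tested (going by the name of the read-out)), compound 1 gives 47.5%. Compound 2 `Nc1scc(-c2cccc(C(F)(F)F)c2)c1C(=O)c1ccccc1` carries hydrogen instead, and compound 2 gives 61.1%, so a number 13.6 percentage points higher from compound 1 to compound 2 (beyond the scatter). Compound 3 `Nc1sc(-c2ccccc2)c(-c2cccc(C(F)(F)F)c2)c1C(=O)c1ccccc1` carries phenyl, and compound 3 gives 82.4%, the highest of the three; the steps of a number 34.9 percentage points higher from compound 1 to compound 3 (beyond the scatter) and a number 21.3 percentage points higher from compound 2 to compound 3 (beyond the scatter) both lie beyond the scatter.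

Compound 4 `CC(=O)c1cccc(-c2sc(N)c(C(=O)c3ccccc3)c2-c2cccc(C(F)(F)F)c2)c1` keeps the phenyl of compound 3 and changes it by acetyl in place of hydrogen on an aromatic carbon. None of the three measured steps touches this outer phenyl ring; all of them concern the exchange of bromo, hydrogen and phenyl on the core, so they give no direct guide to what an acetyl on the phenyl does. In the absence of such a guide, compound 4 is expected to stay near compound 3, with a step of a number 4.4 percentage points lower from compound 3 to compound 4 (within the scatter) that need not exceed the scatter. The estimate for compound 4 is 78%, within a range from 60% to 92%.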

Compound 4, a percentage reported as inhibition, at one concentration (the size of the read-out at that concentration, not a potency): 33.1%
Estimate against measurement, compound 4: 44.9 percentage points above; the measured number lies below the stated range.
By their numbers in this assay, from the lowest: compound 4; then compound 1; then compound 2; then compound 3.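

Placing an acetyl on the outer phenyl ring, meta to a large group, gives a number 49.3 percentage points lower from compound 3 to compound 4 (beyond the scatter) in this assay, so a ring that stayed unchanged in the earlier compounds turns out to have a strong influence on this read-out. The earlier compounds shown here placed phenyl above both hydrogen and bromo at the varied carbon of the core, but the order reverses with 3-acetylphenyl there: in place of hydrogen it gives a number 28 percentage points lower from compound 2 to compound 4 (beyond the scatter), and in place of bromo it gives a number 14.4 percentage points lower from compound 1 to compound 4 (beyond the scatter). Nothing given here explains why this small addition has such a large effect.

Among the compounds shown here, with only one group at one place on this ring, it remains open whether the drop belongs to the acetyl itself or would also appear with a methyl, a hydroxyl or an amine in the same place. Going by these compounds, it is equally open whether an acetyl elsewhere on the outer phenyl ring would give a similar number, and because each reading comes from one concentration, how potency changes also remains unknown.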